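A few compounds are considered here, and "the series" means these few. Any claim that something is new, unique, unknown or untested is made for them only; others in the source may bear on it.

In a functional assay on T29Kt1 cells (Homo sapiens) for cytotoxicity, read by sulforhodamine B assay, with a stated time of 3 days (a lower number here means a stronger inhibitor, a higher number a weaker inhibitor), compound 1 `O=Cc1cn(Cc2cccc(Cl)c2)c2ccc(F)cc12` gives 1500 nM and compound 2 `O=Cc1cn(Cc2ccc(Cl)cc2)c2ccc(F)cc12` gives 9090 nM on their shared core. Compound 3 `OCc1cn(Cc2ccccc2Cl)c2ccccc12` gives 2510 nM and stands within the scatter of compound 1, while the number for compound 2 is higher, beyond the scatter. Compound 4 `OCc1cn(Cc2ccc(Cl)cc2Cl)c2ccccc12` differs from compound 3 by chloro in place of hydrogen on an aromatic carbon with chloro in place of hydrogen on an aromatic carbon, meta to a chloro group and para to a large group. Among the measured compounds shown here, no measured pair shows this change alone, so only a small move towards a lower number in this assay is expected, possibly none beyond the scatter. The estimated step is a 1.4-fold lower number from compound 3 to compound 4 (0.14 log units; within the scatter) on present data. For compound 4 the expected value is 1800 nM with an estimated range from 600 nM to 5000 nM for now.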

Compound 4, half-maximal inhibitory concentration: 1580 nM
For compound 4 the middle estimate is 1.1-fold (0.06 log units) above the measured one, within the range that was stated.
By their numbers in this assay, from the lowest: compounds 1, 4 and 3 (each within the scatter of the next); then compound 2.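

In this assay, among the compounds shown here, chloro in place of hydrogen on an aromatic carbon, meta to a chloro group and para to a large group, gives a 1.6-fold lower number from compound 3 to compound 4 (0.20 log units; within the scatter) and forms the first pair that differs in one place. At this position, the added chloro gives no change that can be told from the scatter. No evidence at hand bears on this step. Going by these compounds, whether a methoxy group or an amine on this carbon would give a step beyond the scatter remains open. Also open, on these data alone, is whether the same chloro change would behave alike on the core of compound 1.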